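Swapping phenylcarbamoyl for cyclopropylsulfonyl on the shared core

The source may hold more compounds than are shown below. What is called first, only, known or untested is meant among the compounds shown, and "the series" means these compounds.

Compound 1 `Cc1ccc(-c2c(C)c(-c3ccc(C)c(C)c3)c(C(OC(C)(C)C)C(=O)O)c(C)c2NC(=O)Nc2ccccc2)cc1C` is tested in an ADME assay on MT4 cells (Homo sapiens) for cytotoxicity, read by MTT assay, with a stated time of 4 days; a lower number here means that less compound is tolerated, a higher number that more compound is tolerated; there compound 1 gives 8000 nM, the lowest of the two numbers in hand. Compound 2 `Cc1ccc(-c2c(C)c(-c3ccccc3)c(C(OC(C)(C)C)C(=O)O)c(C)c2NS(C)(=O)=O)cc1C` reaches only a limit of the assay, > 50000 nM. Compound 3 `Cc1ccc(-c2c(C)c(-c3ccc(Cl)c(F)c3)c(C(OC(C)(C)C)C(=O)O)c(C)c2NS(C)(=O)=O)cc1C` gives 22000 nM, so compound 1 sits a clear gap below it. Among the measured compounds shown here, the single measured step, an at least 2.2-fold lower number from compound 2 to compound 3 (0.35 log units; beyond the scatter), changes the aryl group and leaves the group on the ring nitrogen untouched, so it does not bear directly on the step to compound 4. Compound 4 `Cc1ccc(-c2c(C)c(-c3ccc(C)c(C)c3)c(C(OC(C)(C)C)C(=O)O)c(C)c2NS(=O)(=O)C2CC2)cc1C` differs from compound 1 by cyclopropylsulfonyl in place of phenylcarbamoyl on a nitrogen on an aromatic ring, which one bond further out reads (phenylcarbamoyl)amino to (cyclopropylsulfonyl)amino. For the measured compounds named here, no measured pair isolates this change; the only hint is that the two compounds without phenylcarbamoyl, compounds 2 and 3, both sit at higher numbers than compound 1. A modest rise is therefore expected, with wide uncertainty. Compound 4 is estimated at 20000 nM, within 8000 nM to 50000 nM, an expected step of a 2.5-fold higher number from compound 1 to compound 4 (0.40 log units; beyond the scatter).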

Compound 4, half-maximal cytotoxic concentration: 11000 nM
Compound 4: middle estimate off by 1.8-fold (0.26 log units), on the high side; the measured number falls inside the stated range.
By their numbers in this assay, from the lowest: compounds 1, 4 and 3 (each within the scatter of the next, the first and the last beyond it). At a limit, above all of these: compound 2.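

In this assay the position on the nitrogen on an aromatic ring gives its first direct reading: a 1.4-fold higher number from compound 1 to compound 4 (0.14 log units; within the scatter). Phenylcarbamoyl and cyclopropylsulfonyl, which differ in ring, heavy-atom count and hydrogen-bond donors, therefore cannot be told apart here, so this swap alone does not separate compound 4 from compound 1, whereas the earlier step reported only on the aryl group. Nothing on hand gives a cause for this result.

From the compounds shown here alone, how an acetyl group or a longer alkyl chain on that nitrogen would read in this assay remains open. Also open, going by these compounds, is whether replacing the aryl group with 4-chloro-3-fluorophenyl would shift the number on the cyclopropylsulfonyl compounds as it does on the methylsulfonyl pair, compounds 2 and 3.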